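Tert-butyl for cyclohexyl on the tetrazole nitrogen

The source may report more compounds than this note shows. Statements on the series, on what has been measured and on what is new or still open speak of the compounds shown alone.

Compound 1 `CC1(c2ccc(NC(c3ccc(Br)cc3)c3nnnn3C3CCCCC3)cc2)NC(=O)c2ccccc2N1` is the reference point for this step. In an ADME assay on Vero cells (Chlorocebus sabaeus) for cytotoxicity, read by MTT assay, with a stated time of 72 h (a lower number here means that less compound is tolerated, a higher number that more compound is tolerated), compound 1 gives only a limit of the assay, > 400000 nM, not a number. Compound 2 `CC(C)c1ccc(C(Nc2ccc(C3(C)NC(=O)c4ccccc4N3)cc2)c2nnnn2C2CCCCC2)cc1` carries isopropyl in place of bromo on an aromatic carbon; in this assay compound 2 likewise gives only the limit > 400000 nM. The step that the two limits leave unreadable from compound 1 to compound 2 therefore cannot be read in size or direction. Compound 3 `COc1ccc(C(Nc2ccc(C3(C)NC(=O)c4ccccc4N3)cc2)c2nnnn2C2CCCCC2)cc1` has "not determined" (no result reported) in this assay, so it adds no number either. The only firm fact is the limit of > 400000 nM in this assay, at which 2 of the 3 values shown sit.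

Compound 4 `CC1(c2ccc(NC(c3ccc(Br)cc3)c3nnnn3C(C)(C)C)cc2)NC(=O)c2ccccc2N1` differs from compound 1 as follows: tert-butyl in place of cyclohexyl on an aromatic nitrogen. Going by the values given here, no measured step touches this aromatic nitrogen, so none of them bears directly on the change. With both measured values resting at the limit, there is no ground to expect a readable move in this assay for compound 4; the expected step of a number no higher from compound 1 to compound 4 (the limit leaves the size open) from compound 1 to compound 4 is set at no change beyond the scatter. For compound 4 in this assay the estimate is 400000 nM, with a range from 150000 nM to 1000000 nM, and most likely the assay will again report only a limit.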

Compound 4, half-maximal cytotoxic concentration: > 400000 nM
Compound 4 ended at the assay's limit; the forecaster's own chance of this, stated with the estimate: 80%; the middle value lies on the limit itself.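

In this assay compound 4 gives > 400000 nM as a limit of the assay and not a number. Going by these compounds alone, compound 1 also rests on a limit, so no step between compound 1 and compound 4 can be read. The compounds shown leave open whether tert-butyl in place of cyclohexyl on the aromatic nitrogen changes the result in this assay at all.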